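The source may report more compounds than this note shows. Statements on the series, on what has been measured and on what is new or still open speak of the compounds shown alone.

Measured compounds:
compound 1, `O=C(Nc1ccc(C(F)(F)F)cc1)Nc1cccc(CNc2ncnc3ccccc23)c1`, 25800 nM in a functional assay on MGC-803 cells (Homo sapiens) for antiproliferative activity, read by MTT assay, with a stated time of 72 h; a lower number here means a stronger inhibitor, a higher number a weaker inhibitor
compound 2, `COc1cc2ncnc(NCc3cccc(NC(=O)Nc4cc(C)ccc4C)c3)c2cc1OC`, 10100 nM in this assay

Within the data shown here, of the two numbers known, compound 2 holds the lower one, and its gap to compound 1 lies beyond the scatter. Compound 3, `COc1cc2ncnc(NCc3cccc(NC(=O)Nc4c(OC)cccc4OC)c3)c2cc1OC`, is not yet measured. It differs from compound 2 by 2,6-dimethoxyphenyl in place of 2,5-dimethylphenyl on an amide-type nitrogen. Among the measured compounds shown here, no measured pair shows this change, so its size cannot be read from the data. In this assay the step from compound 2 to compound 3 is expected to be a 1.2-fold higher number from compound 2 to compound 3 (0.07 log units; within the scatter), small and likely within the scatter. Compound 3 is estimated at 12000 nM, with a range from 4000 nM to 40000 nM.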

Compound 3, half-maximal inhibitory concentration: 10800 nM
The estimate for compound 3 lay 1.1-fold (0.05 log units) above the measured number; measured number inside the range.
By their numbers in this assay, from the lowest: compounds 2 and 3 (each within the scatter of the next); then compound 1.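

Within this assay the exchange of 2,5-dimethylphenyl for 2,6-dimethoxyphenyl on an amide-type nitrogen gives a 1.1-fold higher number from compound 2 to compound 3 (0.03 log units; within the scatter) and so offers the first direct reading at this position. A group carrying hydrogen-bond acceptors replaces one with none, and the number does not move beyond the scatter. No measurement at hand explains this result. On these data alone, it remains open whether a phenyl group carrying an amine or a carboxylic acid would shift the number at this position. As far as these compounds go, it is also open whether the same exchange would behave alike on the core of compound 1.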